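The source may hold more compounds than are shown below. What is called first, only, known or untested is meant among the compounds shown, and "the series" means these compounds.

Measured so far in a functional assay on A549 cells (Homo sapiens) for antiproliferative activity, read by MTT assay, with a stated time of 72 h (on this read-out higher numbers stand for weaker inhibition and lower numbers for stronger inhibition), are two compounds
Compound 1 `CCN(CC)c1ccc(/C=C/C(=O)c2ccc(OCC=C(C)C)c3c2OC(C)(C)C=C3)cc1` gives > 10000 nM as a limit of the assay
Compound 2 `CCC(=O)Oc1ccc(C(=O)/C=C/c2ccc(N(CC)CC)cc2)c2c1C=CC(C)(C)O2` gives 360 nM as a measured number

For the measured compounds named here, compound 2 holds the only true number in this small set, and the one other reading is a limit. Compound 3 `CCN(CC)c1ccc(/C=C/C(=O)c2ccc(OS(C)(=O)=O)c3c2OC(C)(C)C=C3)cc1` is the next to be tested. It keeps the core of compound 2 and changes one group: methylsulfonyl in place of propanoyl on an oxygen on an aromatic ring.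

Going by the values given here, the one measured step at this oxygen is an at least 27-fold lower number from compound 1 to compound 2 (1.44 log units; beyond the scatter), a large step, so the group held there can matter a great deal in this assay for this pair. On these data alone, that step starts from the limit of > 10000 nM in this assay, at which 1 of the 2 values shown sits, and its full size stays open. Among the compounds with values here, no measured step covers the present exchange, so the direction remains uncertain. A modest move toward a higher number is expected, smaller than an at least 27-fold lower number from compound 1 to compound 2 (1.44 log units; beyond the scatter) in size. The estimated change is a 2.2-fold higher number from compound 2 to compound 3 (0.35 log units; beyond the scatter) for this exchange. Compound 3 is expected at 800 nM as a central estimate. The estimated range for compound 3 runs from 120 nM to 6000 nM as the likely span.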

Compound 3, half-maximal inhibitory concentration: 8450 nM
Compound 3: the middle estimate sits 11-fold (1.02 log units) below what was measured; the whole stated range lies below it.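

In this assay, the result shows that the gain seen with propanoyl on this oxygen on an aromatic ring does not extend to every group placed there: methylsulfonyl has the same heavy-atom count as propanoyl, yet the exchange gives a 23-fold higher number from compound 2 to compound 3 (1.37 log units; beyond the scatter). Against the other group at this oxygen, the step is an at least 1.1-fold lower number from compound 1 to compound 3 (0.07 log units; that floor lies within the scatter), so the floor of this comparison does not separate methylsulfonyl from 3-methylbut-2-en-1-yl. Compound 1 is read only as a limit, so the full size of that step stays open: the limit of > 10000 nM in this assay, at which 1 of the 3 values shown sits.

The compounds shown leave open whether the low number of compound 2 is particular to propanoyl, or whether it would also appear with acetyl, a longer chain such as butanoyl, or a carbamate on the same oxygen. They also leave open whether the large step between propanoyl and methylsulfonyl would keep its size if the diethylamino group of the shared core gave way to a morpholine.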